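From limit to number: replacing the 2-oxopyrrolidin-1-yl group

The compounds below may be only part of what the source reports. "The series", "measured", "known", "first", "only" and "open" are said of these compounds alone.

Measured in an ADME assay on microsomes from liver (Mus musculus) for metabolic stability; on this read-out lower numbers stand for slow clearance and higher numbers for fast clearance
compound 1 `Cc1n[nH]c(-c2ncc3c(NCc4ccc(Cl)cc4)ccnc3c2O)n1` gives 3.4 mL.min-1.g-1
compound 2 `Cc1n[nH]c(-c2ncc3c(N4CCCC4=O)ccnc3c2O)n1` gives < 0.5 mL.min-1.g-1 (a limit)

For compound 2 the value < 0.5 mL.min-1.g-1 is a limit of the assay and not a number. Compound 2 therefore has no exact place on the scale. Compound 3 `COc1ccccc1-c1ccnc2c(O)c(-c3nc(C)n[nH]3)ncc12` is not yet measured. The change 2-methoxyphenyl in place of 2-oxopyrrolidin-1-yl on an aromatic carbon is 2-methoxyphenyl in place of 2-oxopyrrolidin-1-yl on an aromatic carbon, opposite the ring nitrogen. Going by the values given here, no measured pair shows this change alone. Among the compounds with values here, the only guide to a number is compound 1 at 3.4 mL.min-1.g-1 in this assay on the shared core. An upward move beyond the scatter is expected, with the estimated step of an at least 6.0-fold higher number from compound 2 to compound 3 (0.77 log units; beyond the scatter) as the working figure. For compound 3 the estimated value is 3 mL.min-1.g-1 with an expected range of 1 mL.min-1.g-1 to 9 mL.min-1.g-1 on this estimate.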

Compound 3, intrinsic clearance in microsomes: 0.8 mL.min-1.g-1
The estimate for compound 3 lay 3.8-fold (0.57 log units) above the measured number; the whole stated range lies above it.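

In this assay the 2-methoxyphenyl group gives this position a number where the 2-oxopyrrolidin-1-yl group gave only a limit, and the change reads as an at least 1.6-fold higher number from compound 2 to compound 3 (0.20 log units; that floor lies within the scatter). This figure is only a floor and shows no rise beyond the scatter; its true size stays unread because compound 2 rests on a limit: the limit of < 0.5 mL.min-1.g-1 in this assay, at which 1 of the 3 values shown sits. On the shared core, compound 1 gives 3.4 mL.min-1.g-1 and compound 3 gives 0.8 mL.min-1.g-1, so a six-membered aromatic ring of carbon only on this aromatic carbon gives the lower of these two numbers.

On these data alone, how far compound 2 lies under its limit remains open. Also open, as far as these compounds go, is how a plain phenyl, or a phenyl carrying a carboxylic acid or an amine, would read at this position.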